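The compounds below may be only part of what the source reports. "The series", "measured", "known", "first", "only" and "open" are said of these compounds alone.

Measured so far in a functional assay on HeLa cells (Homo sapiens) for cytotoxicity, read by MTT assay, with a stated time of 72 h; on this read-out higher numbers stand for weaker inhibition and lower numbers for stronger inhibition:

Compound 1, `COc1ccc(C(=O)c2cc(OC)c(OC)c(OC)c2)cc1NC(=O)/C=C/c1cc(OC)c(OC)c(OC)c1`: 1500 nM
Compound 2, `COc1cc(C(=O)c2cc(OC)c(OC)c(OC)c2)cc(NC(=O)/C=C/c2cc(OC)c(OC)c(OC)c2)c1OC`: 2500 nM

Only these two numbers are known, and compound 2 stands at the higher end of them, though the gap to compound 1 is small: a 1.7-fold higher number from compound 1 to compound 2 (0.22 log units; within the scatter). That step added a methoxy group to an aromatic carbon, and the result stayed within the scatter.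

Compound 3, `COc1ccc(/C=C/C(=O)Nc2cc(C(=O)c3cc(OC)c(OC)c(OC)c3)cc(OC)c2OC)cc1OC`, is the next step from compound 2. The change is hydrogen in place of methoxy on an aromatic carbon. Among the compounds with values here, it is the same kind of change as the one from compound 1 to compound 2, only run the other way: a methoxy group is taken away rather than added. Since that earlier step moved the number within the scatter, no shift beyond the scatter is expected here either. For compound 3 the estimate in this assay is therefore 2000 nM, between 900 nM and 4500 nM, a step of a 1.3-fold lower number from compound 2 to compound 3 (0.10 log units; within the scatter) from compound 2 that is expected to be small.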

Compound 3, half-maximal inhibitory concentration: 2700 nM
Compound 3: the middle estimate sits 1.4-fold (0.13 log units) below what was measured, within the range that was stated.
By their numbers in this assay, from the lowest: compounds 1, 2 and 3 (each within the scatter of the next).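

Going from the 3,4,5-trimethoxyphenyl group to the 3,4-dimethoxyphenyl group gives a 1.1-fold higher number from compound 2 to compound 3 (0.03 log units; within the scatter) in this assay. Within the data shown here, the earlier methoxy step sat on the other aromatic ring, so this is the first look at this ring, and here too the methoxy change stays within the scatter. Losing this one methoxy group, with two others still on the ring, therefore leaves no readable mark on the number in this assay. Nothing measured here bears on what lies behind this result.

Still open, going by these compounds, is whether a hydroxyl group, an amine or a longer alkoxy chain in this place would also stay within the scatter. Also open, on these data alone, is what happens when a second methoxy group leaves this ring.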